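From 3-methylphenyl to 2-iodophenyl: an expected toxicity step

The source may hold more compounds than are shown below. What is called first, only, known or untested is meant among the compounds shown, and "the series" means these compounds.

In a toxicity assay on L02 cells (Homo sapiens) for cytotoxicity, read by MTT assay, with a stated time of 24 h (on this read-out lower numbers stand for higher toxicity in this test and higher numbers for lower toxicity in this test), compound 1 `COc1cc(/C=C/C(=O)OCC(C)C)ccc1OS(=O)(=O)c1ccc(Cl)cc1` gives 103000 nM and compound 3 `CCCCS(=O)(=O)Oc1ccc(/C=C/C(=O)Nc2ccc(Cl)cc2)cc1OC` gives 81200 nM while compound 2 `CCCCS(=O)(=O)Oc1ccc(/C=C/C(=O)Nc2cccc(C)c2)cc1OC` gives 33600 nM as the lowest of the three numbers. Compound 2 is therefore the most toxic of the three in this test.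

Compound 4 `CCCCS(=O)(=O)Oc1ccc(/C=C/C(=O)Nc2ccccc2I)cc1OC` keeps the rest of compound 2 and changes one group, with 2-iodophenyl in place of 3-methylphenyl on an amide-type nitrogen as the whole difference. Within the data shown here, one measured step bears on this change. Placing 4-chlorophenyl on that same nitrogen gave a 2.4-fold higher number from compound 2 to compound 3 (0.38 log units; beyond the scatter) and that step is modest. Among the measured compounds shown here, no measured compound carries a 2-iodophenyl group, so this single step is only a loose guide and the range must stay wide.

A modest rise of similar size is expected, estimated as a 2.2-fold higher number from compound 2 to compound 4 (0.35 log units; beyond the scatter) in this assay. The estimate for compound 4 is 75000 nM with an expected range from 25000 nM to 200000 nM in the measurement to come.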

Compound 4, half-maximal cytotoxic concentration: 24500 nM
Beside the measured number, compound 4's estimate is 3.1-fold (0.49 log units) above it, and the stated range ends above it.
By their numbers in this assay, from the lowest: compounds 4 and 2 (each within the scatter of the next); then compounds 3 and 1 (each within the scatter of the next).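

On an amide-type nitrogen, 2-iodophenyl in place of 3-methylphenyl gives a 1.4-fold lower number from compound 2 to compound 4 (0.14 log units; within the scatter) in this assay, so this test does not separate these two groups. Compared with the 4-chlorophenyl group, the same 2-iodophenyl group gives a 3.3-fold lower number from compound 3 to compound 4 (0.52 log units; beyond the scatter), which shows that the higher number seen with compound 3 does not follow simply from having a halogen atom on this phenyl ring, as compound 4 goes against any such pattern. Nothing available explains why these groups differ in this way.

The compounds shown leave open how far this position can be changed before the number moves by more than the scatter, since they carry only methyl, chloro and iodo groups on this phenyl ring. A phenyl ring bearing an amine or a carboxylic acid at this nitrogen would test the position with a very different kind of group.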